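A few compounds are considered here, and "the series" means these few. Any claim that something is new, unique, unknown or untested is made for them only; others in the source may bear on it.

Working notes on the series. Compound 1 `C[C@@H](Cn1ccc(-c2ccc(C#N)c(Cl)c2)n1)NC(=O)c1ccccc1` carries a benzoyl group on the amine nitrogen. In an ADME assay on PC-3 cells (Homo sapiens) for cytotoxicity, read by CCK-8 assay, with a stated time of 6 days (on this read-out higher numbers stand for weaker inhibition and lower numbers for stronger inhibition), compound 1 gives only a limit of the assay, > 30000 nM. Compound 2 `C[C@@H](Cn1ccc(-c2ccc(C#N)c(Cl)c2)n1)NC(=O)c1ccccc1F` differs by fluoro in place of hydrogen on an aromatic carbon. In this assay compound 2 likewise reaches only a limit, > 30000 nM. Compound 3 `C[C@@H](Cn1ccc(-c2ccc(C#N)c(Cl)c2)n1)Nc1ncccn1` has pyrimidin-2-yl in place of benzoyl on the amine nitrogen. In this assay compound 3 also gives a limit, > 30000 nM. The measured steps are a step that the two limits leave unreadable from compound 1 to compound 2, a step that the two limits leave unreadable from compound 1 to compound 3 and a step that the two limits leave unreadable from compound 2 to compound 3, and none of them can be read because of the limit of > 30000 nM in this assay, at which 3 of the 3 values shown sit. Compound 3 thus stands at the limit, with no number that would set it apart from compound 1 or compound 2.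

Compound 4 `Cc1ccnc(N[C@@H](C)Cn2ccc(-c3ccc(C#N)c(Cl)c3)n2)n1` is the next step: methyl in place of hydrogen on an aromatic carbon. Within the data shown here, no measured step bears on a methyl entering at this place, and the steps that are measured, from the amide to the pyrimidine and the added fluoro, are all unreadable between limits. With three limits and no readable step, no shift in this assay beyond the scatter is expected. The estimated step is a step that the limit leaves unreadable from compound 3 to compound 4. For compound 4 in this assay the expected value is 40000 nM, with a range from 15000 nM to 150000 nM, most likely again reported only as a limit.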

Compound 4, half-maximal inhibitory concentration: > 30000 nM
Compound 4 ended at the assay's limit (the forecaster's own chance of this, stated with the estimate: 85%); the middle value lies beyond the limit too.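

In this assay compound 4 gives > 30000 nM, which is a limit of the assay. The steps to compound 4 from compound 1, compound 2 and compound 3 cannot be read, because the values coincide at that limit: the limit of > 30000 nM in this assay, at which 4 of the 4 values shown sit.

The compounds shown leave open whether any group on the amine nitrogen gives a number rather than a limit in this assay.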